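Isopropyl in place of benzyl in compound 2

The source may report more compounds than this note shows. Statements on the series, on what has been measured and on what is new or still open speak of the compounds shown alone.

Compound 1 `CCOC(=O)NC/C=C\CN(C)C[C@H]1O[C@@H](n2c(C)nc3c(N)ncnc32)[C@H](O)[C@@H]1O`: > 1.5 h, a limit of the assay
Compound 2 `Cc1nc2c(N)ncnc2n1[C@@H]1O[C@H](CN(C)C/C=C\CNC(=O)OCc2ccccc2)[C@@H](O)[C@H]1O`: 0.4 h

Within the data shown here, in an ADME assay on microsomes from liver (Homo sapiens) for metabolic stability, read by LC-MS, using NADPH, tested at 1 uM (on this read-out higher numbers stand for a longer-lived compound and lower numbers for a shorter-lived compound), compound 2 gives 0.4 h, the only true number so far. The sole other result, for compound 1, is > 1.5 h, a limit of the assay. Compound 3 `Cc1nc2c(N)ncnc2n1[C@@H]1O[C@H](CN(C)C/C=C\CNC(=O)OC(C)C)[C@@H](O)[C@H]1O` has not yet been measured. It carries isopropyl in place of benzyl on an oxygen next to a carbonyl group. Among the measured compounds shown here, one measured step bears on this change: an at least 3.7-fold lower number from compound 1 to compound 2 (0.57 log units; beyond the scatter). There, phenyl takes the place of methyl on a saturated chain carbon bound to an oxygen next to a carbonyl group. Compound 3, like compound 1, has no ring at this place, so a rise of similar size is expected. The expected change is a 3.5-fold higher number from compound 2 to compound 3 (0.54 log units; beyond the scatter), upward and beyond the scatter. For compound 3 the estimate is 1.4 h, with an expected range of 0.7 h to 3 h.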

Compound 3, half-life: > 1.5 h
Compound 3: only a limit was reported; the forecaster's own chance of this, stated with the estimate: 45%; middle value at least 1.0-fold (0.02 log units) from the limit.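

In this assay, isopropyl in place of benzyl on an oxygen next to a carbonyl group gives an at least 3.7-fold higher number from compound 2 to compound 3 (0.57 log units; beyond the scatter). The earlier step had changed benzyl only against the ethyl carbamate of compound 1, whereas this second group without a ring shows that the low number of compound 2 is not particular to that one comparison. Compound 3 gives > 1.5 h, a limit of the assay.

As far as these compounds go, the step between compound 1 and compound 3 cannot be read, so these two groups cannot be ordered: the limit of > 1.5 h in this assay, at which 2 of the 3 values shown sit. Also open is whether the low number of compound 2 goes with its aromatic ring or with the larger group as a whole, which a cyclohexylmethyl group on the same oxygen would help to separate.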